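Methoxy on the anilino ring of a thiazolyl acetamide

The compounds below may be only part of what the source reports. "The series", "measured", "known", "first", "only" and "open" are said of these compounds alone.

Compound 1, `Cc1nc(SCC(=O)Nc2nc(-c3ccc(Cl)cc3)cs2)n(Nc2ccccc2)c1C`: 1400 nM
Compound 2, `Cc1ccc(Nn2c(SCC(=O)Nc3nc(-c4ccccc4)cs3)nc(C)c2C)cc1`: 1850 nM

Of the compounds shown here, two have been measured in a functional assay on T47D cells (Homo sapiens) for antiproliferative activity, read by sulforhodamine B assay, with a stated time of 48 h; a lower number here means a stronger inhibitor of growth, a higher number a weaker inhibitor of growth. Compound 1 gives 1400 nM, the lowest of the two numbers. Its nearest neighbour is compound 2, which in this assay gives 1850 nM; the two values lie within the scatter of each other, so no order between them can be read. The two structures differ in more than one place, so their values show only that both sit in the same range.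

The next compound, compound 3, `COc1ccc(Nn2c(SCC(=O)Nc3nc(-c4ccc(Cl)cc4)cs3)nc(C)c2C)cc1`, is not yet measured. It differs from compound 1 by methoxy in place of hydrogen on an aromatic carbon. Among the compounds with values here, no step of this kind has been measured here. Given that compound 1 gives 1400 nM and compound 2 gives 1850 nM, a small step, if any, is expected, in no clear direction beyond the scatter.

Compound 3 is therefore estimated at 1300 nM, within 600 nM to 2800 nM, a step of a 1.1-fold lower number from compound 1 to compound 3 (0.03 log units; within the scatter).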

Compound 3, concentration for 50% growth inhibition: 1230 nM
Estimate against measurement, compound 3: 1.1-fold (0.02 log units) above; low and high end bracket the measured number.
By their numbers in this assay, from the lowest: compounds 3, 1 and 2 (each within the scatter of the next).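

In this assay, within the data shown here, the change from anilino to (4-methoxyphenyl)amino, with methoxy para to a large group, gives a 1.1-fold lower number from compound 1 to compound 3 (0.06 log units; within the scatter) and is the only single-place comparison available in this set. It shows that this position of the anilino ring accepts a methoxy group in place of hydrogen, with compound 3 remaining in the same range as compound 1 and compound 2. No supporting measurement is available to explain this result.

The compounds shown leave open whether a larger or differently functionalised para substituent, such as a dimethylamino group, a carboxylic acid or a longer butoxy chain, would also leave the number within this range. They also leave open whether methoxy would behave the same way at another carbon of this ring, or with the chlorine absent from the other aromatic ring.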